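Phenyl in place of methyl on the chain of compound 1

The source may report more compounds than this note shows. Statements on the series, on what has been measured and on what is new or still open speak of the compounds shown alone.

For the measured compounds named here, compound 1 (`CCCCOc1ccc2c(Cl)ccnc2c1`) gives 3050 nM in a functional assay on RKO cells (Homo sapiens) for cytotoxicity, read by MTT assay, with a stated time of 48 h (a higher number here means a weaker inhibitor, a lower number a stronger inhibitor), and so holds the higher of the two numbers known so far. Compound 2 (`CN(C)CCCNc1ccnc2cc(OCc3ccc(F)cc3)ccc12`) gives 1230 nM in this assay as well, a lower number whose gap to compound 1 lies beyond the usual scatter. These two compounds differ in more than one place, so their pair isolates no single change.

Compound 3 (`Clc1ccnc2cc(OCCCc3ccccc3)ccc12`) has not yet been measured. Its difference from compound 1 is this: phenyl in place of methyl on a saturated chain carbon, three bonds along the chain from an oxygen on an aromatic ring. Going by the values given here, no measured pair shows what such a change does in this assay so the expectation is weakly founded. Only a modest move towards a lower number is expected, and it may well stay within the scatter. The estimated step is a 1.3-fold lower number from compound 1 to compound 3 (0.10 log units; within the scatter) and no larger move is expected. For compound 3 the expected value is 2400 nM with an estimated range from 800 nM to 6000 nM as its upper end.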

Compound 3, half-maximal inhibitory concentration: 1420 nM
For compound 3 the middle estimate is 1.7-fold (0.23 log units) above the measured one; the range from low to high includes it.
By their numbers in this assay, from the lowest: compounds 2 and 3 (each within the scatter of the next); then compound 1.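

In this assay, for the compounds shown here, the change from methyl to phenyl, on a saturated chain carbon three bonds along the chain from an oxygen on an aromatic ring, gives a 2.1-fold lower number from compound 1 to compound 3 (0.33 log units; beyond the scatter) and is the first step that isolates a single change. It shows that this place on the chain accepts a six-membered aromatic ring of carbon only, a change that adds no hydrogen-bond donors or acceptors, and that the number falls modestly rather than rises. No measurement at hand accounts for this fall.

The compounds shown leave open whether the fall depends on the aromatic ring itself or on the added carbons alone, a question that a cyclohexyl ring or a plain longer chain at the same place would address. Also open, from the compounds shown here alone, is how far the distance from the oxygen to the phenyl matters, and what a methoxy group, an amine or a carboxylic acid on that phenyl would do to the number in this assay on the same core.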